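Working notes: single stereocentre inversion, compound 3 to compound 4

This account rests on a few compounds, and the source may have more. Where it says the series, first, only, none or still open, it means among the compounds named here.

Measured so far in a functional assay on HOP-62 cells (Homo sapiens) for inhibition; on this read-out higher numbers stand for weaker inhibition of growth and lower numbers for stronger inhibition of growth:
compound 1, `C=C1CCCC(C)(C)C1CC[C@]1(C)CC[C@H]([C@@H](C)C(=O)OC)OO1`, gives 710 nM.
compound 2, `C=C1CCCC(C)(C)C1(O)CC/C(C)=C/CC[C@]1(C)CC[C@@H]([C@@H](C)C(=O)OC)OO1`, is reported only as a limit, > 17500 nM.
compound 3, `CC1=C(CC/C(C)=C/CC[C@@]2(C)CC[C@@H]([C@H](C)C(=O)O)OO2)C(C)(C)CCC1`, is reported only as a limit, > 100000 nM.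

Compound 3 stands at the limit of > 100000 nM in this assay, at which 1 of the 3 values shown sits, the upper of the two limits among the three values shown. Compound 2 sits at the other one, (the limit of > 17500 nM in this assay, at which 1 of the 3 values shown sits). Compound 1 alone has a number in this assay.

Compound 4, `CC1=C(CC/C(C)=C/CC[C@@]2(C)CC[C@H]([C@H](C)C(=O)O)OO2)C(C)(C)CCC1`, differs from compound 3 as follows: the two compounds have the same atoms and bonds and differ only in configuration as drawn: 1 of 4 stereo elements differ; a stereocentre at a saturated ring carbon is drawn S in compound 3 and R in compound 4. Among the measured compounds shown here, no step between two measured compounds differing in one place is available, so the size of this change has no precedent here. A step of about none beyond the scatter is expected, a number no higher from compound 3 to compound 4 (the limit leaves the size open), with compound 4 most likely again reported as a limit. Compound 4 is therefore estimated at 100000 nM, within 30000 nM to 300000 nM.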

Compound 4, concentration for 50% growth inhibition: > 5000 nM
Compound 4: only a limit was reported; the forecaster's own chance of this, stated with the estimate: 75%; the middle value is on the limit's open side.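

In this assay compound 3 is reported only as a limit (> 100000 nM). Compound 4 is also reported only as a limit (> 5000 nM). Among the compounds shown here, no step can therefore be read between compound 3 and compound 4. The compounds shown leave open whether the configuration at this saturated ring carbon affects growth inhibition at all.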